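Aryl substituent variation on the shared core

The source may report more compounds than this note shows. Statements on the series, on what has been measured and on what is new or still open speak of the compounds shown alone.

Measured compounds:
- compound 1, `NC(=O)Nc1sc(-c2ccc(C(=O)N3CCOCC3)cc2)cc1C(=O)N[C@H]1CCCNC1`: "not determined" (no result reported) in an assay on isolated protein for inhibition of cyclin-dependent kinase 2-associated protein 1 (Homo sapiens); on this read-out lower numbers stand for stronger inhibition and higher numbers for weaker inhibition
- compound 2, `NC(=O)Nc1sc(-c2ccc(Cl)cc2)cc1C(=O)N[C@H]1CCCNC1`: 3700 nM in this assay
- compound 3, `NC(=O)Nc1sc(-c2ccc(N)cc2)cc1C(=O)N[C@H]1CCCNC1`: "not determined" (no result reported) in this assay

Compound 3 stands without a number in this assay, reported as "not determined" (no result reported); compound 1 likewise carries none, reported as "not determined" (no result reported), so compound 2 is the only measured point in the set. The step from compound 3 to compound 4, `CN(C)c1ccc(-c2cc(C(=O)N[C@H]3CCCNC3)c(NC(N)=O)s2)cc1`, is dimethylamino in place of amino on an aromatic carbon. Within the data shown here, no measured pair covers this change, so its direction and size cannot be read from the numbers, and nothing beyond the usual scatter can be claimed for it. Any expectation therefore rests on compound 2 alone, which gives 3700 nM in this assay. Compound 4 is expected to fall near that region, estimated at 3000 nM with a range from 600 nM to 15000 nM.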

Compound 4, half-maximal inhibitory concentration: 8400 nM
For compound 4 the middle estimate is 2.8-fold (0.45 log units) below the measured one; measured number inside the range.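

In this assay, among these compounds, dimethylamino in place of chloro on the aromatic carbon gives a 2.3-fold higher number from compound 2 to compound 4 (0.36 log units; beyond the scatter), the first measured step at this position. It shows that the read-out responds to the group here, and that a change from chloro to dimethylamino moves it modestly, not sharply, towards weaker inhibition. No measured evidence accounts for this step.

Steps involving compound 1 or compound 3 cannot be read, so the amino to dimethylamino change remains unresolved. Also open, on these data alone, is how a carboxylic acid, a methoxy group or a longer alkyl chain at this position would read.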